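A few compounds are considered here, and "the series" means these few. Any claim that something is new, unique, unknown or untested is made for them only; others in the source may bear on it.

Compound 1 `CC(C)(C)OC(=O)c1cccc(NC(=O)C2CCCN(C(=O)c3cc(C(F)(F)F)cc(C(F)(F)F)c3)C2)c1` and compound 2 `O=C(Nc1cccc(Oc2ccccc2)c1)C1CCCN(C(=O)c2cccc(-c3ccco3)c2)C1` were both examined in an ADME assay on PC-3 cells (Homo sapiens) for cytotoxicity, read by WST assay, tested at 100 uM (a higher number here means more inhibition at the concentration tested (going by the name of the read-out), a lower number less inhibition), where a reading of inhibition at a single concentration is taken. In this assay compound 1 gives 0%, and compound 2 gives 0%. Compound 2 thus stands level with compound 1 at the digits shown, its nearest neighbour, with no change between the two within the scatter of the measurement. Compound 3 `O=C(Nc1cccc(Cc2ccccc2)c1)C1CCCN(C(=O)c2cccc(-c3ccco3)c2)C1` has not yet been measured. It differs from compound 2 in one place: benzyl in place of phenoxy on an aromatic carbon. Both measured compounds show no inhibition at all, and nothing in the record points to a step from this exchange, so the step estimated in this assay is no change at the digits printed from compound 2 to compound 3 (within the scatter), none beyond the scatter. The estimate for compound 3 in this assay is therefore 0%, with an expected range from -5% to 12%.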

Compound 3, a percentage reported as inhibition, at one concentration (the size of the read-out at that concentration, not a potency): 0%
Compound 3: the middle estimate sits on the measured number at the digits printed, and the stated range covers the measured number.
By their numbers in this assay, from the lowest: compounds 1, 2 and 3 (each within the scatter of the next).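

Benzyl in place of phenoxy on an aromatic carbon, meta to a large group, gives no change at the digits printed from compound 2 to compound 3 (within the scatter) in this assay and is the first exchange at a single place that can be read here, since compound 1 and compound 2 differ in more than one place. At this position, then, a group with no hydrogen-bond acceptor can stand in for one with a single acceptor, and compound 3 still reads 0% at the one concentration tested. Nothing available explains this result.

Since all three readings coincide, the compounds shown cannot tell whether this position has any bearing on the read-out at all. As far as these compounds go, whether an amine, a carboxylic acid or a longer alkyl chain in this place would give a step beyond the scatter remains open.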